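Methyl for acetyl in compound 3

The source may hold more compounds than are shown below. What is called first, only, known or untested is meant among the compounds shown, and "the series" means these compounds.

Of the compounds shown here, three with a shared core have been tested so far: compound 1 (`CC(C)(C)NC(=O)COC(=O)c1ccc([N+](=O)[O-])o1`), compound 2 (`CC(C)(C)N(CCC(=O)c1ccccc1)C(=O)COC(=O)c1ccc([N+](=O)[O-])o1`) and compound 3 (`CC(=O)Oc1ccc(CN(C(=O)COC(=O)c2ccc([N+](=O)[O-])o2)C(C)(C)C)cc1`). In an ADME assay on MT4 cells (Homo sapiens) for cytotoxicity, read by MTT assay, with a stated time of 3 days (on this read-out higher numbers stand for lower toxicity in this test and lower numbers for higher toxicity in this test), compound 1 gives > 100000 nM, which is a limit of the assay and not a number. In this assay compound 2 is reported as "not active" (no number reported), with no number given. In the same test compound 3 gives > 100000 nM, again only a limit. Compound 3 therefore stands with the limit of > 100000 nM in this assay, at which 2 of the 3 values shown sit, and no exact value fixes its place.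

Compound 4 (`COc1ccc(CN(C(=O)COC(=O)c2ccc([N+](=O)[O-])o2)C(C)(C)C)cc1`) keeps the core of compound 3 and changes one group: methyl in place of acetyl on an oxygen on an aromatic ring. This puts methyl in place of acetyl on an oxygen on an aromatic ring, turning 4-acetoxyphenyl into 4-methoxyphenyl. Going by the values given here, no measured pair shows what this change does. The expectation rests on compound 3 and its limit of > 100000 nM. No step beyond the usual scatter, in either direction, is expected in this assay, and the estimated step is a number no higher from compound 3 to compound 4 (the limit leaves the size open). For compound 4 the expected value is 100000 nM, with an estimated range of 30000 nM to 200000 nM.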

Compound 4, half-maximal cytotoxic concentration: > 100000 nM
Compound 4: no number, only a limit (the forecaster's own chance of this, stated with the estimate: 75%); the middle value lies on the limit itself.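

Going by these compounds alone, compound 1, compound 3 and compound 4 all stand only as limits in this assay, and no step from compound 3 or compound 1 to compound 4 can be read. The compounds shown leave open at what concentration any of them would harm these cells, and whether methyl in place of acetyl shifts that concentration.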